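Step from compound 1 to compound 3

The source may report more compounds than this note shows. Statements on the series, on what has been measured and on what is new or still open speak of the compounds shown alone.

Measured so far:
- compound 1 `C#CCSc1nc(Nc2ccc(C)cc2)c2ccncc2n1`: 8090 nM
- compound 2 `C#CCSc1nc(Nc2ccc(OC)cc2)c2ccncc2n1`: > 80000 nM

For the measured compounds named here, in a functional assay on MGC-803 cells (Homo sapiens) for inhibition, read by MTT assay, with a stated time of 72 h (a lower number here means a stronger inhibitor, a higher number a weaker inhibitor), compound 1 gives 8090 nM, the only true number so far. Compound 2 stands at > 80000 nM, which is a limit of the assay and not a number.

Compound 3 `C#CCSc1nc(Nc2cccc(O)c2)c2ccncc2n1` has not yet been measured in this assay. Its change from compound 1 is 3-hydroxyphenyl in place of 4-methylphenyl on a nitrogen on an aromatic ring.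

Going by the values given here, the only measured step that bears on this is an at least 9.8-fold higher number from compound 1 to compound 2 (0.99 log units; beyond the scatter), with methoxy in place of methyl on an aromatic carbon. On these data alone, that step ends at the limit of > 80000 nM in this assay, at which 1 of the 2 values shown sits, so its full size stays open. It concerns a different group, so it gives a direction more than a size. On the strength of an at least 9.8-fold higher number from compound 1 to compound 2 (0.99 log units; beyond the scatter), a more moderate rise in this assay is expected, with a wide margin.

The expected step is a 2.7-fold higher number from compound 1 to compound 3 (0.43 log units; beyond the scatter). For compound 3 the estimated value is 22000 nM, with an expected range of 6000 nM to 80000 nM.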

Compound 3, half-maximal inhibitory concentration: 15700 nM
For compound 3 the middle estimate is 1.4-fold (0.15 log units) above the measured one, within the range that was stated.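

In this assay, 3-hydroxyphenyl in place of 4-methylphenyl on the nitrogen gives a 1.9-fold higher number from compound 1 to compound 3 (0.29 log units; within the scatter). This place on the shared core therefore tolerates a change of the whole aryl group, including the entry of a hydrogen-bond donor and acceptor, with no step beyond the scatter. Compound 2 remains a limit of the assay and not a number: the limit of > 80000 nM in this assay, at which 1 of the 3 values shown sits.

The removal of the methyl, the entry of the hydroxyl and the different ring placement all arrive together in compound 3, and the compounds shown cannot separate their contributions. On these data alone, whether an amine or a carboxylic acid on that phenyl ring would also give a true number in this assay remains open.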